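Turning One Stereocentre: From Compound 2 to Compound 3

The source may report more compounds than this note shows. Statements on the series, on what has been measured and on what is new or still open speak of the compounds shown alone.

Measured so far:
Compound 1, `CN1C[C@H](C[N+](C)(C)C)OC1=O`: 3100 nM
Compound 2, `CN1CCC[C@H]1[C@H]1COC(=O)N1`: 14000 nM

Two compounds have numbers in an assay on Hippocampus for displacement of a labelled ligand from Neuronal acetylcholine receptor; alpha4/beta2 (Rattus norvegicus); on this read-out higher numbers stand for weaker inhibition and lower numbers for stronger inhibition. Compound 1 gives 3100 nM and compound 2 gives 14000 nM. Compound 2 thus stands at the highest of the two numbers, that is the weaker of the two; the gap to compound 1 lies beyond the scatter of this assay. Within the data shown here, no pair measured so far differs in only one place, so there is no measured step to lean on.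

Compound 3, `CN1CCC[C@H]1[C@@H]1COC(=O)N1`, is the next compound to be measured in this assay. Compared with compound 2, (the two compounds have the same atoms and bonds and differ only in configuration as drawn: 1 of 2 stereo elements differ; a stereocentre at a saturated ring carbon is drawn S in compound 2 and R in compound 3). Nothing else moves. Inverting a single stereocentre can leave a number where it is or shift it in either direction, and the two measured compounds give no guide to which way it goes here. The expectation is therefore a step of no more than modest size, with the direction left open; a move within the scatter is the most likely outcome.

On that basis compound 3 is expected to give about 10000 nM in this assay, within a range of 2500 nM to 40000 nM, which as a step from compound 2 means a 1.4-fold lower number from compound 2 to compound 3 (0.15 log units; within the scatter).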

Compound 3, inhibition constant: 9000 nM
Estimate against measurement, compound 3: 1.1-fold (0.05 log units) above; the measured number falls inside the stated range.
By their numbers in this assay, from the lowest: compound 1; then compounds 3 and 2 (each within the scatter of the next).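

In this assay, among these compounds, this is the first step between measured compounds that differ in one place, and it reads a 1.6-fold lower number from compound 2 to compound 3 (0.19 log units; within the scatter). At this saturated ring carbon, then, drawing the stereocentre S or R makes no difference that this read-out can separate from repeat-to-repeat scatter, so configuration at this position gives no measurable handle on the number in this pair. Whatever small gap the pair shows can be tied to that single stereocentre alone, because nothing else separates the two structures: the fact that compounds 2 and 3 differ only in the configuration as drawn

The compounds shown leave open what inverting the second stereocentre would do, since it is drawn the same in both members of the pair and its influence on the number therefore remains untested here. They also leave open whether this position would stay as indifferent to configuration on a shared core that carries an ethyl group or a longer chain in place of the methyl group, or a thiocarbonyl in place of the carbonyl.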